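Nitro on the cinnamoyl ring: ortho versus para

The compounds below may be only part of what the source reports. "The series", "measured", "known", "first", "only" and "open" are said of these compounds alone.

Compound 1 `O=C(/C=C/c1ccccc1)NS(=O)(=O)c1ccccc1` is the starting point. In a functional assay on B16-F10 cells (Mus musculus) for antiproliferative activity, read by ELISA and MTT assay, with a stated time of 48 h (on this read-out lower numbers stand for stronger inhibition and higher numbers for weaker inhibition), compound 1 gives 3.5 ug/mL. Compound 2 `O=C(/C=C/c1ccccc1)NS(=O)(=O)c1ccc(F)cc1` carries a fluorine on the ring attached to the sulfonyl group, and in this assay compound 2 gives 2.1 ug/mL, a step of a 1.7-fold lower number from compound 1 to compound 2 (0.22 log units; within the scatter). Compound 3 `O=C(/C=C/c1ccc([N+](=O)[O-])cc1)NS(=O)(=O)c1ccc(F)cc1` adds a nitro group to the other ring, and in this assay compound 3 gives 2.2 ug/mL, a step of a 1.0-fold higher number from compound 2 to compound 3 (0.02 log units; within the scatter). The change from compound 2 to compound 3 is nitro in place of hydrogen on an aromatic carbon.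

Compound 4 `O=C(/C=C/c1ccccc1[N+](=O)[O-])NS(=O)(=O)c1ccccc1` is not yet measured. It differs from compound 1 by nitro in place of hydrogen on an aromatic carbon. Going by the values given here, this is the same kind of change as the one from compound 2 to compound 3, but not the same: there the nitro group sits para to a large group, here it sits ortho to a large group. The two cores also differ, compound 1 being related to compound 2 by hydrogen in place of fluoro on an aromatic carbon.

Among the compounds with values here, the only measured example of adding a nitro group, from compound 2 to compound 3, moved the number by an amount within the scatter. On that basis the step from compound 1 to compound 4 is expected to be a 1.0-fold lower number from compound 1 to compound 4 (0.01 log units; within the scatter), since the parent compound 1 sits at 3.5 ug/mL and the measured nitro step was a 1.0-fold higher number from compound 2 to compound 3 (0.02 log units; within the scatter). Compound 4 is therefore estimated at 3.4 ug/mL in this assay, with a plausible range from 1.6 ug/mL to 7 ug/mL.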

Compound 4, half-maximal inhibitory concentration: 6 ug/mL
The estimate for compound 4 lay 1.8-fold (0.25 log units) below the measured number, within the range that was stated.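

In this assay, nitro in place of hydrogen on an aromatic carbon, ortho to a large group, gives a 1.7-fold higher number from compound 1 to compound 4 (0.23 log units; within the scatter). Set beside the earlier nitro step, the new step cannot be told apart from it: the same change on two cores in this assay, a 1.0-fold higher number (0.02 log units; within the scatter) from compound 2 to compound 3 and a 1.7-fold higher number (0.23 log units; within the scatter) from compound 1 to compound 4, 1.6-fold (0.21 log units) apart, within the scatter of two such steps. Going by these compounds alone, on these two cores, then, adding a nitro group gives no step beyond the scatter, but this rests on only one pair of steps, and the pair differs in two ways, in where the nitro group sits and in whether the core carries fluoro, so it does not show that either difference is without influence or that the result would hold on any other core.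

Still open, from the compounds shown here alone, is whether a different group on the same aromatic carbon, such as an amine or a carboxylic acid, would give a step beyond the scatter on the core of compound 1. Also open, going by these compounds, is how a nitro group ortho to a large group would behave on the core of compound 2, a comparison that would keep the position fixed and test the core alone.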